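Propyl in place of fluoro: estimating compound 4

The compounds below may be only part of what the source reports. "The series", "measured", "known", "first", "only" and "open" are said of these compounds alone.

Compound 1, `O=C(Nc1cccc(-c2oc3cc(-c4ccc(F)cc4)ccc3c(=O)c2O)c1)c1ccc(F)cc1`, gives 8590 nM in a functional assay on MCF7 cells (Homo sapiens) for antiproliferative activity, read by CCK-8 assay, with a stated time of 72 h; on this read-out lower numbers stand for stronger inhibition and higher numbers for weaker inhibition.
Compound 2, `O=C(Nc1cccc(-c2oc3cc(-c4ccc(F)cc4)ccc3c(=O)c2O)c1)c1ccc(F)cc1F`, gives 13500 nM in this assay.
Compound 3, `CCc1ccc(C(=O)Nc2cccc(-c3oc4cc(-c5ccc(F)cc5)ccc4c(=O)c3O)c2)cc1`, gives 22800 nM in this assay.

Compound 1 has the lowest number of the three. The smallest gap is a 1.6-fold higher number from compound 1 to compound 2 (0.20 log units; within the scatter), which is within the scatter, so these two compounds cannot be ordered. The largest gap is a 2.7-fold higher number from compound 1 to compound 3 (0.42 log units; beyond the scatter), a modest weakening that lies beyond the scatter.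

Compound 4, `CCCc1ccc(C(=O)Nc2cccc(-c3oc4cc(-c5ccc(F)cc5)ccc4c(=O)c3O)c2)cc1`, differs from compound 1 by propyl in place of fluoro on an aromatic carbon. Among the compounds with values here, one measured step bears directly on this: a 2.7-fold higher number from compound 1 to compound 3 (0.42 log units; beyond the scatter), where ethyl replaced fluoro at the same place; propyl is that chain one carbon longer. A second step, a 1.7-fold higher number from compound 2 to compound 3 (0.23 log units; within the scatter), changes the same part of the molecule from a different starting point and stays within the scatter. Nothing in the data shows a longer chain reversing the direction seen with ethyl, so in this assay a modest rise in the number, probably beyond the scatter, is expected for compound 4.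

Compound 4 is therefore estimated at 28000 nM, with a range from 12000 nM to 65000 nM, which means an expected 3.3-fold higher number from compound 1 to compound 4 (0.51 log units; beyond the scatter).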

Compound 4, half-maximal inhibitory concentration: 36800 nM
For compound 4 the middle estimate is 1.3-fold (0.12 log units) below the measured one; low and high end bracket the measured number.
By their numbers in this assay, from the lowest: compounds 1, 2, 3 and 4 (each within the scatter of the next, the first and the last beyond it).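

In this assay, a second alkyl chain now goes the same way as ethyl at this aromatic carbon, para to a large group: propyl in place of fluoro gives a 4.3-fold higher number from compound 1 to compound 4 (0.63 log units; beyond the scatter) as a modest weakening. The extra carbon in the chain cannot be judged on its own, as the step of a 1.6-fold higher number from compound 3 to compound 4 (0.21 log units; within the scatter) leaves compound 3 and compound 4 unordered, so these data show no effect of chain length beyond the shared difference from fluoro. The 4-propylphenyl group does, however, separate itself from the 2,4-difluorophenyl group, with a 2.7-fold higher number from compound 2 to compound 4 (0.44 log units; beyond the scatter) as a modest gap, whereas compound 2 and compound 3 could not be told apart.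

No supporting measurement is available to explain why either alkyl chain gives a higher number than fluoro. From the compounds shown here alone, it remains open whether a longer butyl chain, a branched isopropyl group or a methoxy group at this carbon would give a number nearer to that of compound 1 or would raise it further, and whether an amine or a carboxylic acid there would reverse the direction.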